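A few compounds are considered here, and "the series" means these few. Any claim that something is new, unique, unknown or untested is made for them only; others in the source may bear on it.

Working notes on the series. Compound 1 `O=c1c(C2N=C(c3ccccc3)SS2)coc2ccc(Cl)cc12` is the reference point. Within the data shown here, in a functional assay on OVCAR-3 cells (Homo sapiens) for inhibition, read by sulforhodamine B assay, with a stated time of 48 h, tested at 100 uM (a higher number here means more inhibition of growth at the concentration tested, a lower number less inhibition of growth), compound 1 gives 71%, which is the top number of the two measured so far, though the only other number lies within the scatter of it: compound 2 `O=c1c(C2N=C(c3ccccc3)SS2)coc2cc(Cl)c(Cl)cc12` gives 68% in this assay. Among the measured compounds shown here, the one measured step, a number 3 percentage points lower from compound 1 to compound 2 (within the scatter), adds chloro in place of hydrogen on an aromatic carbon of the fused benzene ring and leaves the read-out essentially where it was.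

Compound 3 `O=c1c(C2N=C(c3ccccc3)SS2)coc2ccccc12` is not yet measured. It differs from compound 1 by hydrogen in place of chloro on an aromatic carbon, so it moves in the opposite sense to the measured step, removing a chloro from the same fused ring rather than adding one. For the measured compounds named here, the only step that bears on it is a number 3 percentage points lower from compound 1 to compound 2 (within the scatter), which was within the scatter, and nothing in hand points to a halogen count on that ring shifting the number. The expectation for compound 3 in this assay is therefore a step of a number 3 percentage points lower from compound 1 to compound 3 (within the scatter), that is none beyond the scatter. Compound 3 is estimated at 68%, in the range 52% to 82%.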

Compound 3, percent growth inhibition at one concentration: 11%
Compound 3: the middle estimate sits 57 percentage points above what was measured; measured number outside the range, below it.
By their numbers in this assay, from the lowest: compound 3; then compounds 2 and 1 (each within the scatter of the next).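

In this assay, among these compounds, the chloro on this aromatic carbon, meta to a fused ring and para to a fused ring, proves to matter far more than the earlier pair suggested: replacing it with hydrogen, the only change between the two structures, gives a number 60 percentage points lower from compound 1 to compound 3 (beyond the scatter). Set beside a number 3 percentage points lower from compound 1 to compound 2 (within the scatter), this shows that the two chloro changes on the fused benzene ring are not interchangeable, as adding a further chloro to compound 1 leaves the read-out in place, whereas removing the existing one takes most of it away. Nothing available on these compounds accounts for the size of this drop.

The compounds shown leave open whether chlorine itself is needed on this carbon or whether another group, such as fluoro, bromo, methyl, methoxy or an amine, would hold the number of compound 1. They also leave open whether the same dependence on this carbon would hold if the phenyl group of the shared core were replaced, for example by a pyridyl group.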